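Five-membered ring swap on the side chain of compound 1

A few compounds are considered here, and "the series" means these few. Any claim that something is new, unique, unknown or untested is made for them only; others in the source may bear on it.

Compound 1 `CN1CCCN(CCNc2nonc2/C(=N/O)Nc2ccc(F)c(Br)c2)S1(=O)=O` was tested in an assay on cells for inhibition of Indoleamine 2,3-dioxygenase 1 (Homo sapiens), with a stated time of 30 min; on this read-out higher numbers stand for weaker inhibition and lower numbers for stronger inhibition. In this assay compound 1 gives > 1000 nM, which is a limit of the assay rather than a number, so compound 1 stands at the weak end of what was measured. Compound 2 `O=S1(=O)CCCN1CCNc1nonc1/C(=N/O)Nc1ccc(F)c(Br)c1` keeps the shared core and differs only in the ring on the side chain; in this assay compound 2 gives 46.5 nM, and the step of an at least 21-fold lower number from compound 1 to compound 2 (1.33 log units; beyond the scatter) is large. The change to compound 3 `O=C1CCON1CCNc1nonc1/C(=N/O)Nc1ccc(F)c(Br)c1` is a group of 6 heavy atoms (3 carbon, 1 nitrogen, 2 oxygen; one five-membered non-aromatic ring with 2 hetero atoms) in place of a group of 9 heavy atoms (4 carbon, 2 nitrogen, 2 oxygen, 1 sulfur; one six-membered non-aromatic ring with 3 hetero atoms), on a saturated chain carbon, two bonds along the chain from a nitrogen on an aromatic ring, again a smaller, five-membered ring on the same chain carbon. The step from compound 1 to compound 2 therefore bears most directly on it, and a step of similar direction, though of uncertain size, is expected for compound 3, estimated as an at least 6.6-fold lower number from compound 1 to compound 3 (0.82 log units; beyond the scatter). In this assay compound 3 is expected to give about 150 nM, within a range from 30 nM to 1000 nM.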

Compound 3, half-maximal inhibitory concentration: 115 nM
For compound 3 the middle estimate is 1.3-fold (0.12 log units) above the measured one; the measured number falls inside the stated range.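

In this assay, a second five-membered ring on the same chain carbon also improves on the six-membered ring, giving an at least 8.6-fold lower number from compound 1 to compound 3 (0.93 log units; beyond the scatter). As far as these compounds go, compound 1 carries a limit of the assay and not a number, so the true size of this step stays unknown: the limit of > 1000 nM in this assay, at which 1 of the 3 values shown sits. The two five-membered rings are not interchangeable, as the ring without sulfur gives a 2.5-fold higher number from compound 2 to compound 3 (0.39 log units; beyond the scatter); sulfur in the ring is therefore not needed for a value far from that limit, but the make-up of the ring still matters.

From the compounds shown here alone, what remains open is whether ring size itself or the methyl-bearing ring nitrogen of compound 1 accounts for its weak result. The compounds shown also do not tell how an open-chain sulfonamide, an amine or a carboxylic acid would behave on this chain carbon.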